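The source may hold more compounds than are shown below. What is called first, only, known or untested is meant among the compounds shown, and "the series" means these compounds.

Measured compounds: compound 1 `Nc1nc(Cl)c2ncn(Cc3ccc(CCl)cc3)c2n1` with 26900 nM; compound 2 `ClCc1cccc(Cn2cnc3c(Cl)nc(Cl)nc32)c1` with 5240 nM; compound 3 `ClCc1ccc(Cn2cnc3c(Cl)nc(Cl)nc32)cc1`, whose value is a limit of the assay, > 100000 nM.

In a functional assay on NCI/ADR-RES cells (Homo sapiens) for cytotoxicity, read by sulforhodamine B assay, with a stated time of 48 h (a higher number here means a weaker inhibitor of growth, a lower number a stronger inhibitor of growth), compound 3 sits at the limit (the limit of > 100000 nM in this assay, at which 1 of the 3 values shown sits). Compound 1 differs from compound 3 by amino in place of chloro on an aromatic carbon, and this gave an at least 3.7-fold lower number from compound 3 to compound 1 (0.57 log units; beyond the scatter). Compound 2 shares atoms with compound 3, joined differently, and the difference between the two cores is not broken down here; compound 2 gives the lowest number of the two measured. Compound 4 `Nc1nc(Cl)c2ncn(Cc3cccc(CCl)c3)c2n1` differs from compound 2 by amino in place of chloro on an aromatic carbon, the same change as that from compound 3 to compound 1. For compound 4 an improvement is expected, estimated at a 2.9-fold lower number from compound 2 to compound 4 (0.46 log units; beyond the scatter), resting on the step from compound 3 to compound 1, an at least 3.7-fold lower number from compound 3 to compound 1 (0.57 log units; beyond the scatter). Compound 4 is therefore expected at 1800 nM, within 500 nM to 7000 nM.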

Compound 4, concentration for total growth inhibition: 20000 nM
For compound 4 the middle estimate is 11-fold (1.05 log units) below the measured one; measured number outside the range, above it.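

In this assay, amino in place of chloro on an aromatic carbon gave a 3.8-fold higher number from compound 2 to compound 4 (0.58 log units; beyond the scatter), whereas the same change on the other core ran the opposite way: the same change on two cores in this assay, an at least 3.7-fold lower number (0.57 log units; beyond the scatter) from compound 3 to compound 1 and a 3.8-fold higher number (0.58 log units; beyond the scatter) from compound 2 to compound 4, at least 14-fold (1.15 log units) apart, beyond the scatter of two such steps. Compound 3 gives > 100000 nM, which is a limit of the assay and not a number. These two pairs show that the change did not carry over between these cores in direction or size, but they do not show why, nor how large the step to compound 1 really is.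

The compounds shown leave open whether a methylamino or a hydroxy group in place of the amino group would move the number the same way on both cores.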